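The compounds below may be only part of what the source reports. "The series", "measured", "known", "first", "only" and "open" are said of these compounds alone.

For the measured compounds named here, in a physicochemical assay for pharmacokinetics (a higher number here means that the compound lasts longer, a lower number that the compound disappears faster), compound 1 `O=C(NCc1cccc(Br)c1)N1C(=O)c2ccccc2S1(=O)=O` gives 0.492 h, the only actual number so far. Compound 2 `O=C(c1ccccc1)N1Cc2ccccc2S1(=O)=O` gives > 166 h, which is a limit of the assay and not a number. Compound 3 `O=C(c1ccccc1)N1Cc2ccccc2C1=O` gives > 166 h, which is likewise a limit and not a number. Compound 4 `O=C(NCc1cccs1)N1C(=O)c2ccccc2S1(=O)=O` has not been measured yet. It keeps the core of compound 1, with thiophen-2-yl in place of 3-bromophenyl on a saturated chain carbon bound to an amide-type nitrogen. Going by the values given here, no measured pair shows a swap of this kind. The expectation rests on compound 1, at 0.492 h, whose core stays unchanged. The expected 1.0-fold higher number from compound 1 to compound 4 (0.01 log units; within the scatter) stays within the usual scatter, with no direction favoured. In this assay compound 4 is estimated at 0.5 h, with an expected range from 0.25 h to 1.1 h.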

Compound 4, half-life: 0.365 h
The estimate for compound 4 lay 1.4-fold (0.14 log units) above the measured number, and the stated range covers the measured number.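

For the compounds shown here, replacing 3-bromophenyl with thiophen-2-yl on the saturated chain carbon bound to an amide-type nitrogen gives the first readable step at this position in this assay (a 1.3-fold lower number from compound 1 to compound 4 (0.13 log units; within the scatter)). With the core of compound 1 kept, the half-life therefore stays short with either of these two aromatic rings, so the short value does not depend on the bromine or the six-membered ring. Nothing shown explains this result.

Still open, from the compounds shown here alone, is whether an amine or a carboxylic acid at this position would shift the half-life beyond the scatter. Going by these compounds, whether a longer chain would do so is equally open.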